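This account rests on a few compounds, and the source may have more. Where it says the series, first, only, none or still open, it means among the compounds named here.

The measured compounds, with their values:

compound 1 `O=C(/C=C/c1ccc([N+](=O)[O-])o1)c1ccc(F)cc1`: 463000 nM
compound 2 `COc1ccc(C(=O)/C=C/c2ccc([N+](=O)[O-])o2)cc1`: 571000 nM
compound 3 `O=C(/C=C/c1ccc([N+](=O)[O-])o1)c1ccco1`: 776000 nM

All three were measured in a toxicity assay on Vero cells (Chlorocebus sabaeus) for cytotoxicity; a lower number here means that less compound is tolerated, a higher number that more compound is tolerated. The three numbers sit close together: compound 1 gives the smallest of them, but compound 2 lies only a 1.2-fold higher number from compound 1 to compound 2 (0.09 log units; within the scatter), and the number for compound 3 is likewise within the scatter of compound 1. Within the data shown here, compound 1 therefore stands at the low end of a narrow band in which no compound is separated from another.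

Compound 4 `O=C(/C=C/c1ccc([N+](=O)[O-])o1)c1ccc(OCc2ccccc2)cc1` is not yet measured in this assay. It differs from compound 1 in one place: benzyloxy in place of fluoro on an aromatic carbon. Among the measured compounds shown here, the only measured step that speaks to this change is the one from compound 1 to compound 2, where a methoxy replaced the fluoro on the same aromatic carbon and the number moved by a 1.2-fold higher number from compound 1 to compound 2 (0.09 log units; within the scatter). For the measured compounds named here, the benzyloxy enters at the same place and carries an oxygen acceptor as the methoxy does, but it is a larger group, and no measured pair covers that further growth. The step from compound 1 to compound 4 is therefore expected to be small, estimated as a 1.3-fold lower number from compound 1 to compound 4 (0.12 log units; within the scatter), with a wide range. Compound 4 is estimated at 350000 nM, between 120000 nM and 900000 nM.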

Compound 4, half-maximal cytotoxic concentration: 515000 nM
Compound 4: middle estimate off by 1.5-fold (0.17 log units), on the low side; measured number inside the range.
By their numbers in this assay, from the lowest: compounds 1, 4, 2 and 3 (each within the scatter of the next).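

In this assay, among these compounds, the earlier compounds had tested only a methoxy at this place on the aromatic carbon, para to a large group, whereas compound 4 carries a benzyloxy with a further six-membered aromatic ring of carbon only, and the exchange for fluoro gives a 1.1-fold higher number from compound 1 to compound 4 (0.05 log units; within the scatter) with no separation from compound 1. The added phenyl on the saturated chain carbon bound to the oxygen gives a 1.1-fold lower number from compound 2 to compound 4 (0.04 log units; within the scatter) and also leaves no readable difference, so growing the group from methoxy to benzyloxy does not move the number out of the scatter. Across fluoro, methoxy and benzyloxy at this one place, compounds 1, 2 and 4 therefore stay in a single band, and neither the size of the group that enters nor the added ring separates them here.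

The compounds shown leave open whether an amine or a carboxylic acid at this place would separate from this band. They also leave open whether the nitro group on the shared core has any bearing on these numbers, since it is present in every compound shown. Nothing at hand gives a measured account of why the number holds steady at this position.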